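This account rests on a few compounds, and the source may have more. Where it says the series, first, only, none or still open, it means among the compounds named here.

Of the compounds shown here, two on a shared core have been measured in a functional assay on YAC-1 cells (Mus musculus); on this read-out higher numbers stand for larger maximal responses and lower numbers for smaller maximal responses. Compound 1, `Nc1nc(O)c2c(n1)n(C1OC(CO)[C@@H](O)[C@H]1O)c(=O)n2Cc1ccc(Cl)c(Cl)c1`, gives 15% in this assay. Compound 2, `C=CCn1c(=O)n([C@@H]2O[C@H](CO)[C@H]3OC(CCC)(CCC)O[C@H]32)c2nc(N)nc(O)c21`, gives 56% in this assay. Compound 1 thus stands lowest of the two numbers, and the gap to compound 2 lies beyond the usual scatter; since compound 2 differs from compound 1 in more than one place, its higher value cannot be tied to any single change.

Compound 3, `Cn1c(=O)n(C2OC(CO)[C@@H](O)[C@H]2O)c2nc(N)nc(O)c21`, has not yet been measured. It differs from compound 1 in one place: hydrogen in place of 3,4-dichlorophenyl on a saturated chain carbon bound to an aromatic nitrogen. Among the measured compounds shown here, no measured pair isolates this change, so its effect is unknown. The only hint is that the measured compound with the smaller group on that nitrogen, compound 2, reaches the larger value, though other parts of compound 2 differ as well. On that basis a moderate upward step is expected, from a number 20 percentage points higher from compound 1 to compound 3 (beyond the scatter), with wide uncertainty. Compound 3 is therefore estimated to reach 35% in this assay, within a range of 10% to 65%.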

Compound 3, largest response reached (reported as maximal response), in percent of the reference or control that the assay uses: 72%
Estimate against measurement, compound 3: 37 percentage points below; measured number outside the range, above it.
By their numbers in this assay, from the lowest: compound 1; then compound 2; then compound 3.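

In this assay, putting hydrogen in place of 3,4-dichlorophenyl on a saturated chain carbon bound to an aromatic nitrogen, which turns a 3,4-dichlorobenzyl group into a methyl group, gives a number 57 percentage points higher from compound 1 to compound 3 (beyond the scatter). Among the compounds shown here, this is the first pair here that differs in only one place, so the size of the change can now be tied to this position: the read-out responds strongly to what this nitrogen carries, and between these two compounds, the methyl group goes with the larger maximal response. The compounds shown offer no measurement that explains why the response moves so far.

As far as these compounds go, with only methyl and 3,4-dichlorobenzyl compared directly, it remains open how the response changes between these two groups, for example with an ethyl group, a longer chain such as n-butyl, or a plain benzyl group without its two chlorine atoms. From the compounds shown here alone, it is also open whether the 3,4-dichlorophenyl ring as a whole or its chlorine atoms account for the step, and how a chain ending in an amine or a carboxylic acid would behave at this position.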